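Amino for Dimethylamino on a Weakly Active Inhibitor

The source may hold more compounds than are shown below. What is called first, only, known or untested is meant among the compounds shown, and "the series" means these compounds.

Compound 1 `CN(C)c1c(C#N)c2c(N)ncnc2n1C` stands at the high end of the three numbers gathered so far. In an assay on isolated protein for inhibition of Leucine-rich repeat serine/threonine-protein kinase 2 (Homo sapiens), read by TR-FRET and LanthaScreen, with stated times of 50 min and 30 min, in the presence of a further agent that is not named here (on this read-out lower numbers stand for stronger inhibition and higher numbers for weaker inhibition), compound 1 gives 4620 nM. Its nearest neighbour is compound 3 `C[C@@H]1CCCN1c1c(C(N)=O)c2c(N)ncnc2n1C`, which in this assay gives 3190 nM; the two values lie within the scatter of each other, so no order between them can be claimed. Far from both lies compound 2 `Cc1nn(CC(C)(C)O)cc1Nc1nc(N)c2c(C#N)c(N3CCC[C@H]3C)n(C)c2n1`, which in this assay gives 49 nM, a gap well beyond the scatter. Compound 2 differs from compound 1 in several places at once, so the two values alone show only that the more elaborate molecule reaches a much lower number.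

Compound 4 `Cn1c(N)c(C#N)c2c(N)ncnc21` has not yet been measured. It differs from compound 1 in one place: amino in place of dimethylamino on an aromatic carbon. Going by the values given here, no single-change step between measured compounds anchors this change; compound 3 carries a different amine together with an amide in place of the nitrile, and its value stays within the scatter of compound 1. The estimated step, a 1.2-fold lower number from compound 1 to compound 4 (0.06 log units; within the scatter), is therefore expected to remain within the scatter. For compound 4 the expected value in this assay is 4000 nM, with a range from 1500 nM to 12000 nM.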

Compound 4, half-maximal inhibitory concentration: 14400 nM
Compound 4: the middle estimate sits 3.6-fold (0.56 log units) below what was measured, and the stated range ends below it.
By their numbers in this assay, from the lowest: compound 2; then compounds 3 and 1 (each within the scatter of the next); then compound 4.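

In this assay, going by these compounds alone, amino in place of dimethylamino on the aromatic carbon next to the ring nitrogen gives a 3.1-fold higher number from compound 1 to compound 4 (0.49 log units; beyond the scatter), the first change at this position that can be read on its own. The step is modest, but it shows that the group on this carbon does matter for the number, and that on the core of compound 1 the smaller amino group goes with weaker inhibition than dimethylamino. Nothing available explains why the number rises with this change.

Going by these compounds, it remains open how methylamino, which would stand between these two groups, or a longer chain such as butylamino would fare on this carbon. On these data alone, it also remains open whether the same change would have a step of similar size on the more elaborate compound 2.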